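Cytotoxicity notes on a phenoxyphenyl pyrazoline sulfonamide series

The compounds below may be only part of what the source reports. "The series", "measured", "known", "first", "only" and "open" are said of these compounds alone.

Measured so far:
- compound 1 `NS(=O)(=O)c1ccc(N2N=C(c3ccc(Oc4ccccc4)cc3)CC2c2ccccc2F)cc1` — 32000 nM
- compound 2 `NS(=O)(=O)c1ccc(N2N=C(c3ccc(Oc4ccccc4)cc3)CC2c2ccccc2Cl)cc1` — 8000 nM
- compound 3 `NS(=O)(=O)c1ccc(N2N=C(c3ccc(Oc4ccccc4)cc3)CC2c2ccc(F)cc2)cc1` — 8000 nM

In an ADME assay on BHK-21 cells (Mesocricetus auratus) for cytotoxicity, read by MTT assay, with a stated time of 72 h (on this read-out higher numbers stand for lower toxicity in this test and lower numbers for higher toxicity in this test), compound 3 stands level with compound 2, the two together giving the lowest numbers of the three; compound 1 sits apart, a 4.0-fold lower number from compound 1 to compound 3 (0.60 log units; beyond the scatter). Between compounds 2 and 3 there is no change at the digits printed from compound 2 to compound 3 (within the scatter).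

Compound 4 `NS(=O)(=O)c1ccc(N2N=C(c3ccc(Oc4ccccc4)cc3)CC2c2cccc(Cl)c2)cc1` is not yet measured. It differs from compound 3 by 3-chlorophenyl in place of 4-fluorophenyl on a saturated ring carbon.

Among the compounds with values here, two measured steps bear on it. Swapping the halogen on the same aromatic carbon gave a 4.0-fold lower number from compound 1 to compound 2 (0.60 log units; beyond the scatter). Moving the fluorine within the phenyl on the saturated ring carbon gave a 4.0-fold lower number from compound 1 to compound 3 (0.60 log units; beyond the scatter). Within the data shown here, neither step starts from compound 3, and no measured pair shows the 3-chlorophenyl group, so the expectation for compound 4 in this assay is a number close to that of compound 3, perhaps somewhat lower, with the step expected as a 1.3-fold lower number from compound 3 to compound 4 (0.12 log units; within the scatter). Compound 4 is therefore estimated at 6000 nM, in a range from 2000 nM to 20000 nM.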

Compound 4, half-maximal cytotoxic concentration: 9000 nM
The estimate for compound 4 lay 1.5-fold (0.18 log units) below the measured number, and the stated range covers the measured number.
By their numbers in this assay, from the lowest: compounds 2, 3 and 4 (each within the scatter of the next); then compound 1.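

In this assay the 3-chlorophenyl group on the saturated ring carbon shows a 1.1-fold higher number from compound 3 to compound 4 (0.05 log units; within the scatter) and a 1.1-fold higher number from compound 2 to compound 4 (0.05 log units; within the scatter), so a third halogenated phenyl falls with the 4-fluorophenyl and 2-chlorophenyl groups. The 2-fluorophenyl group of compound 1 remains the only one apart, with a 3.6-fold lower number from compound 1 to compound 4 (0.55 log units; beyond the scatter), so among these four compounds neither the change of halogen nor its place on this phenyl separates compound 2, compound 3 and compound 4. Nothing available explains why compound 1 stands apart.

The compounds shown leave open whether a plain phenyl, or a phenyl carrying an amine or a carboxylic acid, would fall with compound 1 or with the other three. They also leave open how 3-fluorophenyl and 4-chlorophenyl groups would compare at this carbon.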